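A few compounds are considered here, and "the series" means these few. Any claim that something is new, unique, unknown or untested is made for them only; others in the source may bear on it.

Compound 1 `O=C(O)c1cc(-c2cccs2)ccc1O` is one of two measured compounds. Going by the values given here, in a functional assay on the whole organism for inhibition, with Rattus norvegicus as the target, read by paw edema (on this read-out lower numbers stand for an effect already at smaller amounts and higher numbers for an effect only at larger amounts of compound), compound 1 gives 60 mg/kg, and the only comparison available is compound 2 `CCCCOC(=O)Oc1ccc(-n2cccc2)cc1C(=O)O`, which in this assay gives 52 mg/kg; the two numbers lie within the scatter of each other, so compound 1 stands neither apart from nor behind its sole neighbour. Compound 3 `O=C(O)c1cc(-n2cnnc2)ccc1O` has not yet been measured in this assay. It differs from compound 1 by 4H-1,2,4-triazol-4-yl in place of thiophen-2-yl on an aromatic carbon. Among the compounds with values here, no measured pair shows what such a change does here, so the step of a 1.2-fold higher number from compound 1 to compound 3 (0.07 log units; within the scatter) is expected to stay within the scatter. Compound 3 is estimated at 70 mg/kg, between 30 mg/kg and 160 mg/kg.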

Compound 3, dose for half-maximal effect: > 250 mg/kg
Compound 3: only a limit was reported; the forecaster's own chance of this, stated with the estimate: 15%; middle value at least 3.5-fold (0.55 log units) away from the limit.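

Swapping thiophen-2-yl for 4H-1,2,4-triazol-4-yl, on the carbon meta to the carboxy group and para to the hydroxy group, gives an at least 4.1-fold higher number from compound 1 to compound 3 (0.61 log units; beyond the scatter) in this assay. For compound 3, > 250 mg/kg is a limit of the assay and not a number. This first single-place pair shows that the position does not treat these two five-membered aromatic rings alike.

One pair cannot say whether the ring's nitrogen atoms or some other difference between the rings accounts for the step. On these data alone, how an amine, a carboxylic acid or a longer alkyl chain would fare at this position remains open.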